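The compounds below may be only part of what the source reports. "The series", "measured", "known", "first", "only" and "open" are said of these compounds alone.

Working notes on the series, read in a functional assay (Saphenous vein) for inhibition, with Oryctolagus cuniculus as the target; on this read-out lower numbers stand for tighter binding and higher numbers for weaker binding. Among the compounds with values here, compound 1 (`O=C(O)CCc1cc(Cc2cccnc2)cc2c1CCC(NS(=O)(=O)c1ccc(Cl)cc1)C2`) gives 0.2 nM, the lower of the two numbers so far, and compound 2 (`Cc1c(Cc2cccnc2)cc2c(c1CCC(=O)O)CCC(NS(=O)(=O)c1ccc(Cl)cc1)C2`) gives 158 nM. Next comes compound 3 (`O=C(O)CCC/C=C/c1cc(Cc2cccnc2)cc2c1CCC(NS(=O)(=O)c1ccc(Cl)cc1)C2`), where the change is 5-carboxypent-1-en-1-yl in place of 2-carboxyethyl on an aromatic carbon, with the rest of compound 1 kept.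

Within the data shown here, only one measured step bears on this, and only indirectly. Methyl in place of hydrogen on an aromatic carbon gives a 790-fold higher number from compound 1 to compound 2 (2.90 log units; beyond the scatter), a large step, but it is a different change at a different place. Among the measured compounds shown here, no measured compound varies the acid chain, so the data give no direct size for this step. The large step above does show that a single edit to the shared core can raise the number steeply, so a rise beyond the scatter is expected, though a smaller one than that step.

The estimated step is a 15-fold higher number from compound 1 to compound 3 (1.18 log units; beyond the scatter), towards a higher number. For compound 3 the expected value is 3 nM, with an estimated range from 0.3 nM to 30 nM.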

Compound 3, dissociation constant: 2 nM
Compound 3: middle estimate off by 1.5-fold (0.18 log units), on the high side; the measured number falls inside the stated range.
By their numbers in this assay, from the lowest: compound 1; then compound 3; then compound 2.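

In this assay, swapping 2-carboxyethyl for 5-carboxypent-1-en-1-yl on the aromatic carbon ortho to a fused ring gives a 10-fold higher number from compound 1 to compound 3 (1.00 log units; beyond the scatter), the first measured size for an edit to the acid chain at this position. The longer, unsaturated chain, which still ends in the carboxylic acid, costs less than the methyl change elsewhere on the shared core, a 790-fold higher number from compound 1 to compound 2 (2.90 log units; beyond the scatter), and compound 3 still reads 2 nM, so this position accepts a clear change in chain length and saturation with only a modest rise in the number. Nothing measured here accounts for the size of this step.

On these data alone, the step combines added length with a double bond, so their separate shares remain open; a saturated carboxypentyl chain at the same position would separate them. Also open, as far as these compounds go, is whether the carboxylic acid at the end of the chain is required at all, a question that a primary amide or a tetrazole in its place would address.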